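Swapping the Hydroxycyclohexyl Group for an Oxolanylmethyl Group

A few compounds are considered here, and "the series" means these few. Any claim that something is new, unique, unknown or untested is made for them only; others in the source may bear on it.

Compound 1 `COc1ccc(-c2c(-c3ccc(OC)cc3)n(Cc3ccccc3)c3ncn(CCCO)c(=N)c23)cc1`: 0.36 h
Compound 2 `COc1ccc(-c2c(-c3ccc(OC)cc3)n(Cc3ccccc3)c3ncn([C@@H]4CCCC[C@H]4O)c(=N)c23)cc1`: 0.487 h

Both compounds were tested in an ADME assay on microsomes from liver (Mus musculus, strain CD1) for metabolic stability, read by LC-MS, using NADPH, with a stated time of 60 min; a lower number here means that the compound disappears faster, a higher number that the compound lasts longer. Compound 2 holds the highest of the two numbers, yet the step of a 1.4-fold higher number from compound 1 to compound 2 (0.13 log units; within the scatter) lies within the scatter, so the two compounds cannot be told apart on this assay.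

Compound 3 `COc1ccc(-c2c(-c3ccc(OC)cc3)n(Cc3ccccc3)c3ncn(CC4CCOC4)c(=N)c23)cc1` has not yet been measured. It differs from compound 2 in one place: (oxolan-3-yl)methyl in place of 2-hydroxycyclohexyl on an aromatic nitrogen. Going by the values given here, the only measured step, a 1.4-fold higher number from compound 1 to compound 2 (0.13 log units; within the scatter), also changed the group on this aromatic nitrogen, but kept a hydroxyl in both partners; here the hydroxyl leaves, and no measured step mirrors that. Without a precedent, the expectation for compound 3 is no change beyond the scatter, estimated as a 1.2-fold lower number from compound 2 to compound 3 (0.06 log units; within the scatter). Compound 3 is therefore expected to give about 0.42 h in this assay, within a range from 0.17 h to 1 h.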

Compound 3, half-life: 0.275 h
The estimate for compound 3 lay 1.5-fold (0.18 log units) above the measured number, and the stated range covers the measured number.
By their numbers in this assay, from the lowest: compounds 3, 1 and 2 (each within the scatter of the next).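

In this assay, putting (oxolan-3-yl)methyl in place of 2-hydroxycyclohexyl removes the only hydrogen-bond donor of the group on this aromatic nitrogen, and the outcome is a 1.8-fold lower number from compound 2 to compound 3 (0.25 log units; within the scatter), so the loss of that donor leaves no change that can be told from the scatter. The comparison with the open chain of compound 1 reads the same way, with a 1.3-fold lower number from compound 1 to compound 3 (0.12 log units; within the scatter), so compound 1, compound 2 and compound 3 cannot be told apart on half-life. Nothing among the data shown gives a reason for these numbers.

On these data alone, all three groups on this nitrogen contain oxygen, so whether an amine, a carboxylic acid or a longer chain would move the half-life beyond the scatter stays open. Also open, as far as these compounds go, is whether changes elsewhere on the shared core would matter more than changes at this nitrogen.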